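Shortening the hydroxamic acid linker on the shared core

The source may hold more compounds than are shown below. What is called first, only, known or untested is meant among the compounds shown, and "the series" means these compounds.

Measured compounds:
compound 1, `CN(Cc1nc(C2CCN(Cc3ccccc3)CC2)no1)c1ncc(/C=C/C(=O)NO)cn1`: 55%
compound 2, `Cc1ccc(CN2CCC(c3noc(CN(C)c4ncc(/C=C/C(=O)NO)cn4)n3)CC2)cc1`: 60%

In an assay on isolated protein for inhibition of protein deacetylase HDAC6 (Homo sapiens), read by fluorescence, with a stated time of 1 h, tested at 100 nM (on this read-out lower numbers stand for less inhibition and higher numbers for more inhibition at the one concentration tested (going by the name of the read-out)), compound 1 gives 55%. Among the two measured numbers, compound 1 stands lowest; its nearest neighbour is compound 2 at 60%, and the step of a number 5 percentage points higher from compound 1 to compound 2 (within the scatter) lies within the scatter, so the two values cannot be told apart.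

Compound 3, `CN(Cc1nc(C2CCN(Cc3ccccc3)CC2)no1)c1ncc(C(=O)NO)cn1`, has not yet been measured. Compared with compound 1 the change is hydroxycarbamoyl in place of 2-(hydroxycarbamoyl)ethenyl on an aromatic carbon. Among the measured compounds shown here, the only measured step, a number 5 percentage points higher from compound 1 to compound 2 (within the scatter), concerns a methyl on a distant aromatic carbon and says nothing about the hydroxycarbamoyl or the 2-(hydroxycarbamoyl)ethenyl group. For the measured compounds named here, no measured step therefore bears on the change from compound 1 to compound 3, and the direction of the step in this assay cannot be read from these data.

With that caution, the estimated step is a number 10 percentage points lower from compound 1 to compound 3 (within the scatter), a value expected to sit near or somewhat below compound 1 but well inside a wide range. Compound 3 is estimated at 45%, between 15% and 75%.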

Compound 3, a percentage reported as inhibition, at one concentration (the size of the read-out at that concentration, not a potency): 63%
Compound 3: middle estimate off by 18 percentage points, on the low side; low and high end bracket the measured number.
By their numbers in this assay, from the lowest: compounds 1, 2 and 3 (each within the scatter of the next).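

Swapping 2-(hydroxycarbamoyl)ethenyl for hydroxycarbamoyl on the aromatic carbon of the shared core takes the group from 6 heavy atoms to 4 and removes one double bond outside the aromatic rings, and in this assay this gives a number 8 percentage points higher from compound 1 to compound 3 (within the scatter). Among the compounds shown here, the earlier pair differed only by a methyl on an aromatic carbon, so this is the first sign that the group carrying the hydroxycarbamoyl can be shortened here with no difference that can be told from the usual scatter, at least at the one concentration tested. Nothing available explains this result.

Other groups at this position remain open: a saturated 2-(hydroxycarbamoyl)ethyl chain, a longer chain, or a carboxylic acid in place of the hydroxycarbamoyl could each give a different reading. From the compounds shown here alone, because these are single-concentration readings rather than potencies, it also remains open whether full concentration curves would separate the shorter and longer groups, or whether the methyl on the aromatic carbon would read the same on the shortened compound.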